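Amine substituent exchange on the shared core: efficacy outlook

This account rests on a few compounds, and the source may have more. Where it says the series, first, only, none or still open, it means among the compounds named here.

Compound 3 `COC[C@H](NC1CCN(CCCc2c[nH]c3ccc(-n4cnnc4)cc23)CC1)c1ccccc1` gives 93% in a functional assay on CHO cells for activation of 5-hydroxytryptamine receptor 1D (Homo sapiens), read by GTPgammaS binding; on this read-out higher numbers stand for larger maximal responses and lower numbers for smaller maximal responses. Among the three measured compounds this places compound 3 second highest. Its nearest neighbour is compound 2 `c1ccc(CNCC2CCN(CCCc3c[nH]c4ccc(-n5cnnc5)cc34)CC2)cc1`, which gives 101% in this assay, and the step of a number 8 percentage points lower from compound 2 to compound 3 (within the scatter) lies within the scatter. The furthest is compound 1 `O=S(=O)(NCC1CCN(CCCc2c[nH]c3ccc(-n4cnnc4)cc23)CC1)c1ccccc1`, which gives 73% in this assay; the steps of a number 28 percentage points higher from compound 1 to compound 2 (beyond the scatter) and a number 20 percentage points higher from compound 1 to compound 3 (beyond the scatter) are both beyond the scatter and point the same way.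

Compound 4 `c1ccc2c(c1)CCC2NC1CCN(CCCc2c[nH]c3ccc(-n4cnnc4)cc23)CC1` has not been measured. It differs from compound 3 in one place: 2,3-dihydro-1H-inden-1-yl in place of 2-methoxy-1-phenylethyl on an amine nitrogen. Going by the values given here, no measured step covers this exact exchange. The step that bears on it most is the swap of one aryl-bearing group on the amine for another, a number 8 percentage points lower from compound 2 to compound 3 (within the scatter), which stayed within the scatter. Among the compounds with values here, the only steps beyond the scatter, a number 28 percentage points higher from compound 1 to compound 2 (beyond the scatter) and a number 20 percentage points higher from compound 1 to compound 3 (beyond the scatter), concern the phenylsulfonyl group, which compound 4 does not carry. Compound 4 is therefore expected to stay close to compound 3 in this assay. The expected step of no change at the digits printed from compound 3 to compound 4 (within the scatter) is taken to fall within the scatter. The estimate for compound 4 is 93%, with a range from 78% to 106%.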

Compound 4, largest response reached (reported as efficacy), in percent of the reference or control that the assay uses: 68%
Compound 4: middle estimate off by 25 percentage points, on the high side; measured number outside the range, below it.
By their numbers in this assay, from the lowest: compounds 4 and 1 (each within the scatter of the next); then compounds 3 and 2 (each within the scatter of the next).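

In this assay the aryl-bearing group on the amine nitrogen proves not to be freely exchangeable: a number 25 percentage points lower from compound 3 to compound 4 (beyond the scatter), whereas the earlier exchange of this kind, a number 8 percentage points lower from compound 2 to compound 3 (within the scatter), gave no such separation. With a number 33 percentage points lower from compound 2 to compound 4 (beyond the scatter) and a number 5 percentage points lower from compound 1 to compound 4 (within the scatter), a lower maximal response no longer belongs to the phenylsulfonyl compound alone, since compound 4 carries no phenylsulfonyl group yet cannot be told apart from compound 1 in this read-out. The exchange alters several things at once, removing the methoxy oxygen, adding a five-membered non-aromatic ring and leaving no defined stereocentre, and nothing available here indicates which of these accounts for the result.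

Open, on these data alone, is whether the lower number goes with the closed ring or with the missing methoxy; 1-phenylethyl, an open chain without the methoxy, and 1,2,3,4-tetrahydronaphthalen-1-yl, a larger closed ring, would help to separate the two. The compounds shown also leave open how the two separate enantiomers of the 2,3-dihydro-1H-inden-1-yl amine would compare.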